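Methoxy for chloro on the benzyl arm of compound 2

The source may hold more compounds than are shown below. What is called first, only, known or untested is meant among the compounds shown, and "the series" means these compounds.

Compound 2 `COc1cnc2ccc(=O)n(CCN3CCC(NC(=S)NCc4ccc(Cl)cc4)CC3)c2c1` is one of three thiourea or urea compounds measured in an ADME assay on RAW264.7 cells (Mus musculus) for cytotoxicity, read by MTT assay, with a stated time of 48 h, tested at 100 uM; a higher number here means more inhibition at the concentration tested (going by the name of the read-out), a lower number less inhibition. Compound 1 `O=c1ccc2ncc(F)cc2n1CCN1CCC(NC(=S)NCc2ccc(Cl)cc2)CC1` gives 43.7%, compound 3 `COc1ccc(CNC(=O)NC2CCN(CCn3c(=O)ccc4ncc(OC)cc43)CC2)cc1` gives 39.5%, and compound 2 gives 29.5%, the lowest of the three; its gap to compound 3 lies within the scatter, its gap to compound 1 beyond it. Within the data shown here, the only single-place step known is a number 14.2 percentage points lower from compound 1 to compound 2 (beyond the scatter). Compound 4 `COc1ccc(CNC(=S)NC2CCN(CCn3c(=O)ccc4ncc(OC)cc43)CC2)cc1` differs from compound 2 by methoxy in place of chloro on an aromatic carbon. Among the measured compounds shown here, no measured step covers this exact change, and the one known step involved a different halogen, so only a modest move, or none beyond the scatter, is expected. The step from compound 2 to compound 4 is estimated at a number 1.5 percentage points higher from compound 2 to compound 4 (within the scatter). Compound 4 is therefore expected to give about 31%, between 18% and 44%.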

Compound 4, a percentage reported as inhibition, at one concentration (the size of the read-out at that concentration, not a potency): 19.4%
The estimate for compound 4 lay 11.6 percentage points above the measured number; the range from low to high includes it.
By their numbers in this assay, from the lowest: compound 4; then compounds 2, 3 and 1 (each within the scatter of the next, the first and the last beyond it).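

The benzyl arm proves to be a position that responds in this assay: methoxy in place of chloro gives a number 10.1 percentage points lower from compound 2 to compound 4 (beyond the scatter) and so moves the number as far as the scatter allows to be read. Among the compounds shown, methoxy in place of a halogen lowers the number at both places changed, since the core gives a number 14.2 percentage points lower from compound 1 to compound 2 (beyond the scatter) as well. No measurement at hand bears on why the number falls here. On these data alone, whether an amine or a carboxylic acid on the same aromatic carbon would lower the number too remains open.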